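Changing one ring on the shared core: compound 3

The source may hold more compounds than are shown below. What is called first, only, known or untested is meant among the compounds shown, and "the series" means these compounds.

Compound 1 `Cc1cc(CN2CCN(c3c(Cl)cnc4[nH]c(-c5cnn(C)c5)nc34)CC2)no1`: 1800 nM
Compound 2 `Cc1cc(CN2CCN(c3c(Cl)cnc4[nH]c(-c5cc(C)on5)nc34)CC2)no1`: 1150 nM

In a functional assay on SW-620 cells (Homo sapiens) for inhibition, read by MTT assay, with a stated time of 72 h (a lower number here means a stronger inhibitor of growth, a higher number a weaker inhibitor of growth), compound 2 gives 1150 nM, and compound 1, at 1800 nM, lies within the scatter of it, so the two cannot be told apart. Compound 3 `Cc1cc(CN2CCN(c3c(Cl)cnc4[nH]c(-c5ccoc5)nc34)CC2)no1` changes the same place again: furan-3-yl in place of 5-methyl-1,2-oxazol-3-yl on an aromatic carbon. For the measured compounds named here, only one measured step bears on this, an earlier exchange at that place, a 1.6-fold lower number from compound 1 to compound 2 (0.19 log units; within the scatter), and it stays within the scatter. Going by the values given here, one step is thin evidence, and no furan-3-yl compound has been measured yet. Nothing beyond the scatter is therefore expected, and the estimated step is a 1.2-fold higher number from compound 2 to compound 3 (0.09 log units; within the scatter). Compound 3 is expected at 1400 nM, with an estimated range of 600 nM to 3200 nM.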

Compound 3, concentration for 50% growth inhibition: 6500 nM
Compound 3: middle estimate off by 4.6-fold (0.67 log units), on the low side; the whole stated range lies below it.
By their numbers in this assay, from the lowest: compounds 2 and 1 (each within the scatter of the next); then compound 3.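

Replacing a ring at this position can clearly change growth inhibition in this assay: furan-3-yl brings a 5.7-fold higher number from compound 2 to compound 3 (0.75 log units; beyond the scatter) and a 3.6-fold higher number from compound 1 to compound 3 (0.56 log units; beyond the scatter). The earlier exchange between the two methyl-bearing, nitrogen-containing rings had shown no such separation. Nothing measured here explains the loss.

Furan-3-yl has neither a ring nitrogen nor a methyl group, so these compounds cannot show which absence matters. An unsubstituted 1,2-oxazol-3-yl ring or a methylfuran ring at this position would separate the two.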